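A few compounds are considered here, and "the series" means these few. Any claim that something is new, unique, unknown or untested is made for them only; others in the source may bear on it.

Measured compounds:
- compound 1, `CCCn1c(=O)n(CCCN(C)C)c(=O)c2[nH]cnc21`, giving 43200 nM in an assay on Cerebral cortex for binding affinity to adenosine receptor A1 (Cavia porcellus), read by radioligand binding; on this read-out lower numbers stand for stronger inhibition and higher numbers for weaker inhibition
- compound 2, `CCCn1c(=O)n(CCOCC)c(=O)c2[nH]cnc21`, giving 1900 nM in this assay

Compound 2 stands at the lower of the two numbers in this assay. Going by the values given here, the one step measured between them is a 23-fold lower number from compound 1 to compound 2 (1.36 log units; beyond the scatter), a large step in which a basic amine terminus was replaced by an ether terminus on the chain two bonds from the aromatic nitrogen.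

Compound 3, `CCCn1c(=O)n(CCCOC)c(=O)c2[nH]cnc21`, has not yet been measured. It differs from compound 2 as methoxymethyl in place of ethoxy on a saturated chain carbon, two bonds along the chain from an aromatic nitrogen; the two compounds contain the same atoms, joined differently, and each carries a single ether oxygen in its side chain. Among the compounds with values here, no measured step addresses this kind of rearrangement: the sole step on record, a 23-fold lower number from compound 1 to compound 2 (1.36 log units; beyond the scatter), concerns a change of the chain's terminal group rather than a shift of the oxygen along the chain, so it offers only indirect guidance. In the absence of a step that bears on the change, the expected step is small, a 1.3-fold higher number from compound 2 to compound 3 (0.12 log units; within the scatter), and may not exceed the scatter in either direction. Compound 3 is therefore expected to give about 2500 nM in this assay, within a range from 700 nM to 9000 nM.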

Compound 3, inhibition constant: 12400 nM
Compound 3: middle estimate off by 5.0-fold (0.70 log units), on the low side; the measured number lies above the stated range.
By their numbers in this assay, from the lowest: compound 2; then compound 3; then compound 1.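

In this assay, the side chain proves sensitive to how its atoms are joined: methoxymethyl in place of ethoxy, on a saturated chain carbon, two bonds along the chain from an aromatic nitrogen, gives a 6.5-fold higher number from compound 2 to compound 3 (0.81 log units; beyond the scatter) even though the two groups have the same counts of heavy atoms, hydrogen-bond donors and hydrogen-bond acceptors. Methoxy in place of dimethylamino, on a saturated chain carbon, three bonds along the chain from an aromatic nitrogen, gives a 3.5-fold lower number from compound 1 to compound 3 (0.54 log units; beyond the scatter) as a step of its own, so a single ether oxygen in the chain does not by itself guarantee a number as low as the one reached in a 23-fold lower number from compound 1 to compound 2 (1.36 log units; beyond the scatter) and the position of that oxygen also counts. The data shown offer no evidence on why these steps take the sizes they do.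

Compound 2 and compound 3 differ both in where the oxygen sits and in the length of the carbon end beyond it, so these two features cannot be told apart here. From the compounds shown here alone, how a terminal alcohol, a longer chain such as 4-methoxybutyl, or a carboxylic acid at the chain end would read in this assay remains open.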